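The compounds below may be only part of what the source reports. "The series", "measured", "known", "first", "only" and "open" are said of these compounds alone.

Measured so far:
compound 1 `O=C1NCCN1c1ccc(S(=O)(=O)Nc2ccc3[nH]ccc3c2)cc1` — 87 nM
compound 2 `Cc1ccc(NS(=O)(=O)c2ccc(N3CCNC3=O)cc2)cc1` — 260 nM

In a functional assay on M21 cells (Homo sapiens) for antiproliferative activity, read by sulforhodamine B assay, with a stated time of 48 h (a lower number here means a stronger inhibitor, a higher number a weaker inhibitor), compound 2 gives 260 nM, the higher of the two numbers; compound 1 gives 87 nM, a lower number, and the gap between the two lies beyond the scatter. Compound 3 `Cc1ccccc1NS(=O)(=O)c1ccc(N2CCNC2=O)cc1` remains to be measured. It differs from compound 2 at one place only: 2-methylphenyl in place of 4-methylphenyl on a sulfonamide nitrogen. Among the measured compounds shown here, no measured pair shows this kind of change, so there is no direction to lean on. The step from compound 2 to compound 3 is expected to be small, a 1.2-fold higher number from compound 2 to compound 3 (0.06 log units; within the scatter), likely not beyond the scatter in either direction. For compound 3 the estimate is 300 nM, within a range of 120 nM to 800 nM.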

Compound 3, half-maximal inhibitory concentration: 150 nM
For compound 3 the middle estimate is 2.0-fold (0.30 log units) above the measured one; the range from low to high includes it.
By their numbers in this assay, from the lowest: compounds 1, 3 and 2 (each within the scatter of the next, the first and the last beyond it).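

In this assay the first pair differing in one place, 2-methylphenyl in place of 4-methylphenyl on the sulfonamide nitrogen (a 1.7-fold lower number from compound 2 to compound 3 (0.24 log units; within the scatter)), stays within the scatter. The two methylphenyl groups are therefore not told apart at this position, and the methyl can stand at either of these two places on the ring without a change that can be read. Nothing at hand bears on why the two read alike. Still open, from the compounds shown here alone, is whether a larger change here, such as an ethyl group or a carboxylic acid in place of the methyl, would shift the number beyond the scatter.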